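Succinamide-to-fumaramide step on a fluorinated nucleoside core

A few compounds are considered here, and "the series" means these few. Any claim that something is new, unique, unknown or untested is made for them only; others in the source may bear on it.

Measured compounds:
Compound 1 `CCOC(=O)CCC(=O)NC[C@H]1O[C@@H](n2cc(F)c(=O)[nH]c2=O)C[C@@H]1O`: > 280000 nM
Compound 2 `O=C(O)CCC(=O)NC[C@H]1O[C@@H](n2cc(F)c(=O)[nH]c2=O)C[C@@H]1O`: > 290000 nM

In a functional assay on 791T cells for cytotoxicity against 791T cell line (Homo sapiens) (a lower number here means a stronger inhibitor, a higher number a weaker inhibitor), compound 1 gives only a limit, > 280000 nM. Compound 2 likewise gives only a limit, > 290000 nM. The step that the two limits leave unreadable from compound 1 to compound 2 cannot be read because the limit of > 280000 nM in this assay, at which 1 of the 2 values shown sits, and the limit of > 290000 nM in this assay, at which 1 of the 2 values shown sits, are both limits, so compound 2 stands at the edge of what this assay resolves, with no number of its own.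

Compound 3 `CCCCNC(=O)/C=C/C(=O)NC[C@H]1O[C@@H](n2cc(F)c(=O)[nH]c2=O)C[C@@H]1O` carries the change (2-(butylcarbamoyl)ethenyl in place of 2-carboxyethyl on a carbonyl carbon). Among the compounds with values here, no measured step bears on this change, and the only step is itself unreadable, so nothing in the data points to a shift in either direction. The expectation for compound 3 is therefore a value again at or near the assay's limit, estimated at 250000 nM with a range of 60000 nM to 300000 nM. The step of an at least 1.1-fold lower number from compound 2 to compound 3 (0.06 log units; that floor lies within the scatter) is expected to show no change beyond the scatter, and a further limit rather than a number is the most likely outcome.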

Compound 3, half-maximal inhibitory concentration: > 300000 nM
Compound 3: no number, only a limit; the forecaster's own chance of this, stated with the estimate: 70%; middle value at least 1.2-fold (0.07 log units) away from the limit.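

In this assay compound 3 gives only a limit, > 300000 nM. Within the data shown here, compound 1, compound 2 and compound 3 all stand at limits, so no step among them can be read. The compounds shown leave open whether any change at this carbonyl carbon moves the value in this assay.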